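This account rests on a few compounds, and the source may have more. Where it says the series, first, only, none or still open, it means among the compounds named here.

Going by the values given here, compound 2, `Cc1ccc(Oc2c(/C=N/OCc3snnc3C)c(C)nn2C)cc1`, is one of two compounds measured in a functional assay on Huh-7 cells (Homo sapiens) for inhibition, read by MTT assay, with a stated time of 48 h; on this read-out lower numbers stand for stronger inhibition and higher numbers for weaker inhibition. In this assay compound 2 gives only a limit, > 50000 nM. Compound 1, `Cc1nnsc1CO/N=C/c1c(C)nn(C)c1Oc1ccc(I)cc1`, likewise gives only a limit in this assay, > 50000 nM. The step that the two limits leave unreadable from compound 1 to compound 2 is a change of methyl in place of iodo on an aromatic carbon, and its size cannot be read because of the limit of > 50000 nM in this assay, at which 2 of the 2 values shown sit. Compound 3, `Cc1nnsc1CO/N=C/c1c(C)nn(C)c1Oc1ccc(OC(F)(F)F)cc1`, differs from compound 2 by trifluoromethoxy in place of methyl on an aromatic carbon. No measured step bears on this change, since the only step shown has no readable size and both values recorded in this assay sit at the limit. Compound 3 is therefore expected to remain at the limit in this assay, with no step beyond the scatter expected. Compound 3 is estimated at 80000 nM, between 30000 nM and 300000 nM. The step that the limit leaves unreadable from compound 2 to compound 3 is the expected size of this change.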

Compound 3, half-maximal inhibitory concentration: > 50000 nM
Compound 3 gave a limit, no number (the forecaster's own chance of this, stated with the estimate: 80%); the middle value does not contradict the limit.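

No step can be read among compound 1, compound 2 and compound 3 in this assay, because all three give only a limit: the limit of > 50000 nM in this assay, at which 3 of the 3 values shown sit.

The compounds shown leave open how far apart these three lie and whether any group at this place would give a readable value.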